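The compounds below may be only part of what the source reports. "The series", "measured", "known", "first", "only" and "open" are said of these compounds alone.

Measured compounds:
compound 1, `CN1CCCC(NC(=O)c2ccc(Cl)cc2Cl)(c2ccccc2)C1`: 670 nM
compound 2, `COc1cc(C(F)(F)F)cc(SC)c1C(=O)NC1(c2ccc(Cl)cc2)CCCN(C)C1`: 28 nM

Compound 2 stands lowest of the two numbers in an assay on cells for inhibition of sodium- and chloride-dependent glycine transporter 1 (Homo sapiens); a higher number here means that more compound is needed for the effect, a lower number that less compound is needed; compound 1 gives 670 nM, a higher number, and the gap between the two lies beyond the scatter. Within the data shown here, no step between measured compounds that differ in a single place is available here: compound 1 and compound 2 differ in several places at once, so the value of compound 2 serves as the only anchor for the next change.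

Compound 3, `COc1cc(C(F)(F)F)cc(SC)c1C(=O)NC1(c2ccncc2)CCCN(C)C1`, is not yet measured. It differs from compound 2 by pyridin-4-yl in place of 4-chlorophenyl on a saturated ring carbon. With no measured step of this kind in the set, the expectation rests on the anchor alone: the change is expected to cost some potency, with a step from compound 2 to compound 3 of a 5.4-fold higher number from compound 2 to compound 3 (0.73 log units; beyond the scatter) in this assay, beyond the scatter but moderate. Compound 3 is estimated at 150 nM, with a range from 40 nM to 600 nM.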

Compound 3, half-maximal effective concentration: 60 nM
Compound 3: middle estimate off by 2.5-fold (0.40 log units), on the high side; low and high end bracket the measured number.
By their numbers in this assay, from the lowest: compound 2; then compound 3; then compound 1.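

The saturated ring carbon two ring bonds from the ring nitrogen now has its first single-place step: in this assay, pyridin-4-yl in place of 4-chlorophenyl gives a 2.1-fold higher number from compound 2 to compound 3 (0.33 log units; beyond the scatter) and this modest step lies beyond the scatter. At this position, a six-membered aromatic ring with a hetero atom and a hydrogen-bond acceptor is therefore tolerated on the core of compound 2, with only a modest rise in the number. No measurement here explains the size of this step.

From the compounds shown here alone, it remains open whether plain phenyl, pyridin-3-yl or a saturated piperidin-4-yl at this position would give a number closer to that of compound 2. Going by these compounds, it also remains open whether the same exchange would give a step of similar size on the core of compound 1.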